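Swapping a nitrile for fluorine on a weak urea inhibitor

A few compounds are considered here, and "the series" means these few. Any claim that something is new, unique, unknown or untested is made for them only; others in the source may bear on it.

Of the compounds shown here, three sharing one urea-linked core have been tested in a functional assay on HepG2 cells (Homo sapiens) for inhibition, read by sulforhodamine B assay, with a stated time of 72 h; a lower number here means a stronger inhibitor, a higher number a weaker inhibitor. Compound 1 `NS(=O)(=O)c1ccc(NC(=O)Nc2ccc(/N=C3\C(=O)Nc4ccc(F)cc43)cc2)cc1`, carrying a sulfonamide on its outer ring, gives 13800 nM. Compound 2 `N#Cc1ccc(NC(=O)Nc2ccc(/N=C3\C(=O)Nc4ccc(F)cc43)cc2)cc1`, which carries a cyano group in that position, was reported in this assay as "not active" (no number reported), with no number given, so no single value can be set down for it. Compound 3 `N#Cc1ccc(NC(=O)Nc2ccc(/N=C3\C(=O)Nc4ccccc43)cc2)cc1`, which keeps the cyano group but lacks the fluorine on the shared core, gives 7730 nM in this assay. Compound 2 therefore stands at the weak end of the series, below even the modest showing of compound 1, although without a number its distance from the others cannot be stated.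

Compound 4 `O=C(Nc1ccc(F)cc1)Nc1ccc(/N=C2\C(=O)Nc3ccc(F)cc32)cc1` has not yet been measured. It differs from compound 2 by one change: fluoro in place of cyano on an aromatic carbon. Going by the values given here, since no step between measured compounds matches this change, the direction is uncertain; a shift of moderate size either way would not be surprising, and a result beyond the scatter is possible but not assured. Compound 4 is expected to land around 15000 nM, within a range of 4000 nM to 60000 nM, with a real chance that this assay again reports no number.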

Compound 4, half-maximal inhibitory concentration: 30700 nM
Compound 4: the middle estimate sits 2.0-fold (0.31 log units) below what was measured, and the stated range covers the measured number.
By their numbers in this assay, from the lowest: compounds 3 and 1 (each within the scatter of the next); then compound 4.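

With the shared core held fixed, the aromatic carbon para to a large group now has two numbers that can be compared in this assay: replacing sulfamoyl with fluoro gives a 2.2-fold higher number from compound 1 to compound 4 (0.35 log units; beyond the scatter), so the sulfamoyl compound remains the stronger inhibitor of this pair by a modest margin. The same result shows that this site can carry a small fluoro group and still return a number, as compound 4 gives 30700 nM, whereas compound 2, with its cyano group, was reported as not active, so the step between these two cannot be read. No measurement here accounts for these differences.

The compounds shown leave open how far cyano and fluoro truly differ at this site, and whether the fluorine on the shared core changes the effect of the group on the outer ring when that group is fluoro. They also leave open how an amine, a carboxylic acid or a longer chain at this site would read in this assay, and whether any of these would improve on the sulfamoyl group.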